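Cyanoguanidine variant of the diisopropylphenyl series

This account rests on a few compounds, and the source may have more. Where it says the series, first, only, none or still open, it means among the compounds named here.

Measured so far:
compound 1 `CC(C)c1cccc(C(C)C)c1NC(=O)NC1CCCc2ccccc21` — 850 nM
compound 2 `CCc1cccc(C(C)C)c1NC(=O)NCC1(c2ccccc2)CCCC1` — 25 nM
compound 3 `CC(C)c1cccc(C(C)C)c1/N=C(\N)NCC1(c2ccccc2)CCCC1` — 12000 nM

In an assay on microsomes from intestine for inhibition of acyl-CoA:cholesterol acyltransferase (Oryctolagus cuniculus) (on this read-out higher numbers stand for weaker inhibition and lower numbers for stronger inhibition), compound 3 gives the highest number of the three and is the weakest inhibitor here. Compound 1 gives 850 nM, the nearest value, and compound 2 gives 25 nM, the furthest; both gaps lie beyond the usual scatter. No single-point comparison between measured compounds exists, so the weight of the guanidine versus the urea cannot be separated from the other differences among these three.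

Compound 4 `CC(C)c1cccc(C(C)C)c1/N=C(\NC#N)NCC1(c2ccccc2)CCCC1` differs from compound 3 only in the change (cyano in place of hydrogen on an amine nitrogen), amino to cyanoamino. Given that compound 3 sits at 12000 nM, the expectation for compound 4 is a move toward a lower number, of a size clearly beyond the scatter, the estimated step being an 8.0-fold lower number from compound 3 to compound 4 (0.90 log units; beyond the scatter). The estimate for compound 4 in this assay is 1500 nM, with a range from 200 nM to 12000 nM.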

Compound 4, half-maximal inhibitory concentration: 10000 nM
For compound 4 the middle estimate is 6.7-fold (0.82 log units) below the measured one; measured number inside the range.
By their numbers in this assay, from the lowest: compound 2; then compound 1; then compounds 4 and 3 (each within the scatter of the next).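

In this assay, among these compounds, cyano in place of hydrogen on an amine nitrogen gives a 1.2-fold lower number from compound 3 to compound 4 (0.08 log units; within the scatter), the first single-change comparison in this set. At this position, the amino to cyanoamino change therefore leaves the two compounds indistinguishable, even though cyano adds a nitrile and removes a hydrogen from that nitrogen. No supporting data bear on why this change has so little effect on the read-out.

From the compounds shown here alone, it remains open whether a nitro, methylsulfonyl or carbamoyl group on the same nitrogen would also leave the read-out within the scatter. The urea compounds differ from compound 3 and compound 4 in more than one place, so the effect of replacing the urea carbonyl with the cyanoamino-bearing carbon remains unresolved.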